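This account rests on a few compounds, and the source may have more. Where it says the series, first, only, none or still open, it means among the compounds named here.

Measured so far:
compound 1 `C[C@H](NC(=O)c1nnn(Cc2ccc(F)cc2)c1C(F)(F)F)c1ccc(C(=O)O)cc1`: > 10000 nM
compound 2 `C[C@H](NC(=O)c1c(C(F)(F)F)nnn1CCOc1ccc(F)cc1)c1ccc(C(=O)O)cc1`: 276 nM
compound 3 `CCCc1nnn(Cc2ccc(C(F)(F)F)cc2)c1C(=O)N[C@@H](C)c1ccc(C(=O)O)cc1`: 68.8 nM

All three were run in a functional assay on CHO cells for antagonist activity at prostaglandin E2 receptor EP4 subtype (Homo sapiens), read by calcium flux, with a stated time of 15 min; on this read-out higher numbers stand for weaker inhibition and lower numbers for stronger inhibition. The value of compound 1 is a limit of this assay and not a number (the limit of > 10000 nM in this assay, at which 1 of the 3 values shown sits). Of the two numbers, compound 3 gives the lower and compound 2 the higher, a gap that lies beyond the scatter. Compound 4 `C=CCc1nnn(Cc2ccc(C(F)(F)F)cc2)c1C(=O)N[C@@H](C)c1ccc(C(=O)O)cc1` has not yet been measured in this assay; it differs from compound 3 in one place: vinyl in place of ethyl on a saturated chain carbon bound to an aromatic carbon. No measured step of this kind is in hand among these compounds. The change is small, and no step beyond the scatter is expected in this assay in either direction. For compound 4 the expected value in this assay is 80 nM, in the range 35 nM to 180 nM. The expected step of a 1.2-fold higher number from compound 3 to compound 4 (0.07 log units; within the scatter) sits within the scatter.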

Compound 4, half-maximal inhibitory concentration: > 1000 nM
Compound 4: no number, only a limit; the forecaster's own chance of this, stated with the estimate: 2%; middle value at least 12-fold (1.09 log units) away from the limit.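

The value of compound 4 is a limit and not a number: the limit of > 1000 nM in this assay, at which 1 of the 4 values shown sits. The heavy-atom count stays the same and one double bond outside aromatic rings separates the pair, yet vinyl in place of ethyl gives an at least 14-fold higher number from compound 3 to compound 4 (1.16 log units; beyond the scatter). Going by these compounds alone, this position therefore responds to more than chain length, and the earlier compounds did not show this.

Within the data shown here, this is the only step of its kind, so how far it holds with other substituents on the shared core stays open. A butyl chain, a cyclopropylmethyl group or a propargyl group at this position would show whether the loss is specific to allyl.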